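The source may hold more compounds than are shown below. What is called first, only, known or untested is meant among the compounds shown, and "the series" means these compounds.

Measured compounds in a functional assay on KB cells (Homo sapiens) for cytotoxicity, read by MTT assay; on this read-out higher numbers stand for weaker inhibition and lower numbers for stronger inhibition:
- compound 1 `CCn1cc(-c2nc3ccc([N+](=O)[O-])cc3o2)c(=O)c2cc(F)c(N3CCNC(C)C3)c(F)c21` gives 900 nM
- compound 2 `CCn1cc(C(=O)Nc2ccccc2O)c(=O)c2cc(F)c(N3CCNC(C)C3)c(F)c21` gives 5050 nM
- compound 3 `CCn1cc(C(=O)Nc2ccccc2N)c(=O)c2cc(F)c(N3CCNC(C)C3)c(F)c21` gives 2800 nM

Compound 3 holds the second highest of the three numbers in this assay; its gap to compound 2 is within the scatter, its gap to compound 1 is beyond it. Compound 4 `CCn1cc(C(=O)Nc2cccc([N+](=O)[O-])c2)c(=O)c2cc(F)c(N3CCNC(C)C3)c(F)c21` differs from compound 3 by 3-nitrophenyl in place of 2-aminophenyl on an amide-type nitrogen. Among the measured compounds shown here, the only measured step on this amide side, a 1.8-fold lower number from compound 2 to compound 3 (0.26 log units; within the scatter), lies within the scatter, so a swap of the substituent on the aryl ring of the anilide has so far moved little. For the measured compounds named here, compound 1 carries a nitro group on a different, cyclised arm, so no step is known for it. The expectation for compound 4 in this assay is therefore a 1.1-fold lower number from compound 3 to compound 4 (0.05 log units; within the scatter), no change beyond the scatter. Compound 4 is estimated at 2500 nM, range 900 nM to 7000 nM.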

Compound 4, half-maximal inhibitory concentration: 1700 nM
Compound 4: middle estimate off by 1.5-fold (0.17 log units), on the high side; measured number inside the range.
By their numbers in this assay, from the lowest: compounds 1, 4, 3 and 2 (each within the scatter of the next, the first and the last beyond it).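

In this assay, 3-nitrophenyl in place of 2-aminophenyl on the amide-type nitrogen gives a 1.6-fold lower number from compound 3 to compound 4 (0.22 log units; within the scatter), so these two aryl groups are not told apart. Set against 2-hydroxyphenyl, the same group gives a 3.0-fold lower number from compound 2 to compound 4 (0.47 log units; beyond the scatter), a modest step and the first on this amide side beyond the scatter, while compound 3 remains within the scatter of both. Nothing available here accounts for this step.

On these data alone, whether the step follows the nitro group itself or its place on the ring stays open. Also open, as far as these compounds go, is how 3-aminophenyl or 3-carboxyphenyl on this nitrogen would read in this assay.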